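The source may hold more compounds than are shown below. What is called first, only, known or untested is meant among the compounds shown, and "the series" means these compounds.

Working notes on the series. Three hydroxamic acids built on one shared core have been measured: compound 1 `Cc1ccc(-c2nc(CNc3ccc(C(=O)NO)cc3)n(-c3ccccc3)n2)cc1`, compound 2 `Cc1ccc(-n2nc(-c3ccccc3)nc2CNc2ccc(C(=O)NO)cc2)cc1` and compound 3 `O=C(NO)c1ccc(NCc2nc(-c3ccccc3)nn2-c2ccc(F)cc2)cc1`. In an assay on Sf9 cells for inhibition of protein deacetylase HDAC6 (Homo sapiens), read by fluorescence, with a stated time of 40 min, tested at 100 nM (on this read-out lower numbers stand for less inhibition and higher numbers for more inhibition at the one concentration tested (going by the name of the read-out)), compound 1 gives 62.2%, compound 2 gives 60.7% and compound 3 gives 67.6%; compound 1 sits among the three with its gaps to compound 2 and to compound 3 both within the usual scatter, so no ordering among them can be claimed. For the measured compounds named here, the only step between measured compounds is a number 6.9 percentage points higher from compound 2 to compound 3 (within the scatter), which concerns the aryl on the ring nitrogen rather than the aryl between the two ring nitrogens.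

Compound 4 `Cc1ccc(-c2nc(CNc3ccc(C(=O)NO)cc3)n(-c3ccccc3)n2)s1` differs from compound 1 by 5-methylthiophen-2-yl in place of 4-methylphenyl on an aromatic carbon. Going by the values given here, no measured step changes this position, so the only guidance is indirect: the one recorded aryl substituent swap stayed within the scatter. A step of a number 2.2 percentage points lower from compound 1 to compound 4 (within the scatter) is expected, i.e. none beyond the scatter. For compound 4 the estimate in this assay is 60%, with a range of 44% to 76%.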

Compound 4, a percentage reported as inhibition, at one concentration (the size of the read-out at that concentration, not a potency): 79.7%
The estimate for compound 4 lay 19.7 percentage points below the measured number; measured number above the stated range.
By their numbers in this assay, from the lowest: compounds 2, 1 and 3 (each within the scatter of the next); then compound 4.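

For the compounds shown here, the step of a number 17.5 percentage points higher from compound 1 to compound 4 (beyond the scatter) in this assay shows that the aryl on the aromatic carbon between two ring nitrogen atoms is not indifferent to exchange, whereas the one earlier step, a number 6.9 percentage points higher from compound 2 to compound 3 (within the scatter), concerned the other aryl. The change replaces a six-membered aromatic ring of carbon only with a five-membered aromatic ring with one hetero atom, sulfur, and a methyl group is present on both. Nothing at hand accounts for this step.

Open, from the compounds shown here alone, is whether the step belongs to the sulfur ring itself or needs its methyl, which an unsubstituted thiophen-2-yl, a 5-chlorothiophen-2-yl or a furan-2-yl at this position would separate. Also open, going by these compounds, is whether 5-methylthiophen-2-yl on the ring nitrogen gives a similar step, and how the step reads as a potency rather than at one concentration.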